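The source may report more compounds than this note shows. Statements on the series, on what has been measured and on what is new or still open speak of the compounds shown alone.

Measured so far:
compound 1, `O=C(NNc1nncc2ccccc12)C1CC1c1ccc(OCC(F)(F)F)cc1`, 67000 nM in a functional assay on PC-3 cells (Homo sapiens) for inhibition, read by MTT assay, with a stated time of 72 h; a higher number here means a weaker inhibitor, a lower number a stronger inhibitor 
compound 2, `CCOc1ccc(C2CC2C(=O)NNc2nncc3ccccc23)cc1`, 94000 nM 

Among these two numbers compound 2 has the highest, with compound 1 nearest at a 1.4-fold higher number from compound 1 to compound 2 (0.15 log units; within the scatter). Compound 3, `CC(C)=CCOc1ccc(C2CC2C(=O)NNc2nncc3ccccc23)cc1`, differs from compound 2 by 2-methylprop-1-en-1-yl in place of methyl on a saturated chain carbon bound to an oxygen on an aromatic ring. Among the compounds with values here, the only measured step at this same place, a 1.4-fold higher number from compound 1 to compound 2 (0.15 log units; within the scatter), lay within the scatter, so the weight of evidence points to no step beyond the scatter. Compound 3 is therefore estimated at 85000 nM in this assay, with a range from 30000 nM to 200000 nM, an expected step of a 1.1-fold lower number from compound 2 to compound 3 (0.04 log units; within the scatter).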

Compound 3, half-maximal inhibitory concentration: 81000 nM
Compound 3: the middle estimate sits 1.0-fold (0.02 log units) above what was measured, and the stated range covers the measured number.
By their numbers in this assay, from the lowest: compounds 1, 3 and 2 (each within the scatter of the next).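

In this assay, 2-methylprop-1-en-1-yl in place of methyl gives a 1.2-fold lower number from compound 2 to compound 3 (0.06 log units; within the scatter) and, in place of trifluoromethyl, gives a 1.2-fold higher number from compound 1 to compound 3 (0.08 log units; within the scatter) at this same place. Within the data shown here, the earlier pair compared only two groups of similar size, whereas this entering group has 4 heavy atoms and a double bond, and the number still stays within the scatter. No measured evidence bears on this result. On these data alone, whether an amine or a carboxylic acid at this place would move the number beyond the scatter remains open.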